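A few compounds are considered here, and "the series" means these few. Any claim that something is new, unique, unknown or untested is made for them only; others in the source may bear on it.

Measured in a functional assay on Jurkat cells (Homo sapiens) for antiproliferative activity, read by MTT assay, with a stated time of 72 h; on this read-out lower numbers stand for stronger inhibition and higher numbers for weaker inhibition:
- compound 1 `COc1cc(-n2ncnc2-c2ccc(OC(C)C)cc2)cc(OC)c1OC`: 650 nM
- compound 2 `COc1cc(-n2ncnc2-c2cccc(Cl)c2)cc(OC)c1OC`: > 10000 nM (a limit)
- compound 3 `COc1ccccc1-c1ncnn1-c1cc(OC)c(OC)c(OC)c1`: > 10000 nM (a limit)

Compound 3 gives no number in this assay: compound 3 stands at > 10000 nM, which is a limit of the assay. Compound 3 thus shares the position described by this summary: the limit of > 10000 nM in this assay, at which 2 of the 3 values shown sit. Only compound 1 gives a readable value, 650 nM.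

Compound 4 `COc1cc(-n2ncnc2-c2ccc(F)cc2)cc(OC)c1OC` has not yet been measured. The change that leads to it is 4-fluorophenyl in place of 2-methoxyphenyl on an aromatic carbon. In words, 4-fluorophenyl takes the place of 2-methoxyphenyl, on an aromatic carbon of a five-membered aromatic ring with 3 nitrogen.

One measured step involves the same place, a step that the two limits leave unreadable from compound 2 to compound 3, and it offers no size to carry over. The sole sign that the shared core can reach a readable value is compound 1 at 650 nM, and compound 1 carries a different group from compound 4. A modest gain toward stronger inhibition in this assay is therefore expected, though with little confidence, and compound 4 may also return only a limit.

For compound 4 the estimated value is 6000 nM, with an expected range from 800 nM to 30000 nM. This estimate means an at least 1.6-fold lower number from compound 3 to compound 4 (0.22 log units; that floor lies within the scatter).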

Compound 4, half-maximal inhibitory concentration: > 10000 nM
Compound 4: a limit, no number (the forecaster's own chance of this, stated with the estimate: 50%); middle value at least 1.6-fold (0.22 log units) away from the limit.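

In this assay compound 4 returns a limit and not a number, so 4-fluorophenyl on this aromatic carbon joins 3-chlorophenyl and 2-methoxyphenyl in giving no readable value. Within the data shown here, the one step that can be read is fluoro in place of isopropoxy, which gives an at least 15-fold higher number from compound 1 to compound 4 (1.18 log units; beyond the scatter); a group at the same place on the phenyl ring therefore separates a readable value from a limit, which the earlier compounds, differing in more than that one group, could not show. The steps to compound 4 from compound 2 and from compound 3 cannot be read, as both ends of each are limits, and the series now stands as follows: the limit of > 10000 nM in this assay, at which 3 of the 4 values shown sit.

The compounds shown leave open whether the readable value of compound 1 needs isopropoxy itself, or whether an ethoxy group, a longer ether chain or an amine in that place would also give a number. Going by these compounds, how far compound 2, compound 3 and compound 4 lie from one another also stays unknown, since none of them gives a number in this assay.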